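From oxan-4-yl to (oxan-3-yl)methyl on the ether oxygen

The source may report more compounds than this note shows. Statements on the series, on what has been measured and on what is new or still open speak of the compounds shown alone.

In a functional assay on RS4-11 cells (Homo sapiens) for inhibition, read by CCK-8 assay, with a stated time of 72 h (on this read-out higher numbers stand for weaker inhibition and lower numbers for stronger inhibition), compound 1 `CCN(CC)CCCNc1ccc(S(=O)(=O)NC(=O)c2ccc(N3CCN(CC4=C(c5ccc(C(F)(F)F)cc5)CC(C)(C)CC4)CC3)cc2Oc2cnc3[nH]ccc3c2)cc1[N+](=O)[O-]` reads 3 nM and compound 2 `CN1CCC(CNc2ccc(S(=O)(=O)NC(=O)c3ccc(N4CCN(CC5=C(c6ccc(C(F)(F)F)cc6)CC(C)(C)CC5)CC4)cc3Oc3cnc4[nH]ccc4c3)cc2[N+](=O)[O-])C1` reads 8.3 nM while compound 3 `CC1(C)CCC(CN2CCN(c3ccc(C(=O)NS(=O)(=O)c4ccc(OC5CCOCC5)c([N+](=O)[O-])c4)c(Oc4cnc5[nH]ccc5c4)c3)CC2)=C(c2ccc(C(F)(F)F)cc2)C1` stands highest and weakest of the three at 375 nM on the same scale. Compound 4 `CC1(C)CCC(CN2CCN(c3ccc(C(=O)NS(=O)(=O)c4ccc(OCC5CCCOC5)c([N+](=O)[O-])c4)c(Oc4cnc5[nH]ccc5c4)c3)CC2)=C(c2ccc(C(F)(F)F)cc2)C1` differs from compound 3 by (oxan-3-yl)methyl in place of oxan-4-yl on an oxygen on an aromatic ring with (oxan-3-yl)methyl in place of oxan-4-yl on an oxygen on an aromatic ring. The steps of a 130-fold higher number from compound 1 to compound 3 (2.10 log units; beyond the scatter) and a 45-fold higher number from compound 2 to compound 3 (1.65 log units; beyond the scatter) are large but put (oxan-4-yl)oxy in place of amino groups, and a 2.8-fold higher number from compound 1 to compound 2 (0.44 log units; beyond the scatter) is modest and only swaps one amino group for another. For the measured compounds named here, no measured step alters the oxan group itself, so a small step without a favoured direction is expected in this assay here. Compound 4 is expected at 300 nM with an estimated range from 100 nM to 900 nM on this read-out. The estimate amounts to a 1.3-fold lower number from compound 3 to compound 4 (0.10 log units; within the scatter) as the expected step.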

Compound 4, half-maximal inhibitory concentration: 12 nM
Estimate against measurement, compound 4: 25-fold (1.40 log units) above; measured number outside the range, below it.
By their numbers in this assay, from the lowest: compound 1; then compounds 2 and 4 (each within the scatter of the next); then compound 3.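

In this assay the group on this ether oxygen proves decisive, with a 31-fold lower number from compound 3 to compound 4 (1.49 log units; beyond the scatter) for (oxan-3-yl)methyl in place of oxan-4-yl, so the weak reading of compound 3 does not hold for every ether here. The ether of compound 4 reaches the range of the amino groups, with a 1.4-fold higher number from compound 2 to compound 4 (0.16 log units; within the scatter) inside the scatter, while a 4.0-fold higher number from compound 1 to compound 4 (0.60 log units; beyond the scatter) remains a modest gap. Nothing measured here accounts for the large step. The compounds shown leave open whether the added carbon or the shifted ring attachment carries the step, and how (oxan-4-yl)methyl or oxan-3-yl would read on this oxygen.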